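Benzofuran for thiophene on two related nucleoside cores

The compounds below may be only part of what the source reports. "The series", "measured", "known", "first", "only" and "open" are said of these compounds alone.

Compound 1 `Nc1nc2c(c(-c3cccs3)cn2[C@@H]2O[C@H](CO)[C@@H](O)[C@H]2O)c(=O)[nH]1` carries a thiophen-2-yl group on its fused core. In a functional assay on HCT-116 cells (Homo sapiens), read by MTT assay, with a stated time of 72 h (a higher number here means a weaker inhibitor, a lower number a stronger inhibitor), compound 1 gives 19800 nM. Compound 3 `Nc1nc2c(c(-c3cc4ccccc4o3)cn2[C@@H]2O[C@H](CO)[C@@H](O)[C@H]2O)c(=O)[nH]1` is the same core with the larger group: 1-benzofuran-2-yl in place of thiophen-2-yl on an aromatic carbon. For compound 3 the result in this assay is a limit of the assay, > 100000 nM, and this sits at the limit of > 100000 nM in this assay, at which 1 of the 3 values shown sits. The change therefore shows as an at least 5.0-fold higher number from compound 1 to compound 3 (0.70 log units; beyond the scatter).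

Compound 2 `CN(C)c1ncnc2c1c(-c1cccs1)cn2[C@@H]1O[C@H](CO)[C@@H](O)[C@H]1O` keeps the thiophen-2-yl group but on a different core; how the core of compound 2 differs from the core of compound 1 is not broken down here. For compound 2 the result in this assay is also a limit, > 20000 nM, standing at the limit of > 20000 nM in this assay, at which 1 of the 3 values shown sits.

Compound 4 `CN(C)c1ncnc2c1c(-c1cc3ccccc3o1)cn2[C@@H]1O[C@H](CO)[C@@H](O)[C@H]1O`, not yet measured in this assay, is to compound 2 what compound 3 is to compound 1: 1-benzofuran-2-yl in place of thiophen-2-yl on an aromatic carbon. The place of the change reads the same for both pairs, so this is the same change on a second core. Compound 2 already reaches only a limit, so the outcome for compound 4 can mostly be an expectation of a further limit. The expected step is a step that the limit leaves unreadable from compound 2 to compound 4, resting on the measured at least 5.0-fold higher number from compound 1 to compound 3 (0.70 log units; beyond the scatter) from compound 1 to compound 3. Compound 4 is estimated at 100000 nM, within 30000 nM to 400000 nM, and most likely to be reported as a limit only.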

Compound 4, half-maximal inhibitory concentration: > 20000 nM
Compound 4 ended at the assay's limit; the forecaster's own chance of this, stated with the estimate: 90%; the middle value does not contradict the limit.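

In this assay compound 4 gives > 20000 nM, a limit of the assay. Compound 2 gives > 20000 nM, also a limit. Within the data shown here, with both values at a limit, no step between compound 2 and compound 4 can be read. The compounds shown leave open whether 1-benzofuran-2-yl in place of thiophen-2-yl gives a higher number on the core of compound 2, as it does on the core of compound 1.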